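Cytotoxicity of chromone acrylamides: moving a methyl group

The source may hold more compounds than are shown below. What is called first, only, known or untested is meant among the compounds shown, and "the series" means these compounds.

Measured compounds:
Compound 1 `COc1ccc2c(=O)c(/C=C/C(=O)Nc3cc(C)ccc3C)coc2c1`: 1100000 nM
Compound 2 `COc1ccc2c(=O)c(/C=C/C(=O)NCc3ccc(F)cc3)coc2c1`: 133000 nM
Compound 3 `COc1ccc2c(=O)c(/C=C/C(=O)Nc3ccccc3C)coc2c1`: 59700 nM

The three compounds share one core and differ only in the group on the amide-type nitrogen. In an ADME assay on HepG2 2.2.15 cells (Homo sapiens) for cytotoxicity, read by MTT assay, with stated times of 48 h and 9 days (a lower number here means that less compound is tolerated, a higher number that more compound is tolerated), compound 1 gives the highest number of the three, and compound 3 gives the lowest: compound 2 sits nearest to it, a 2.2-fold lower number from compound 2 to compound 3 (0.35 log units; beyond the scatter), while compound 1 is furthest, an 18-fold lower number from compound 1 to compound 3 (1.27 log units; beyond the scatter). Between the other two, an 8.3-fold lower number from compound 1 to compound 2 (0.92 log units; beyond the scatter).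

Compound 4 `COc1ccc2c(=O)c(/C=C/C(=O)Nc3ccc(C)cc3)coc2c1` has not yet been measured. It differs from compound 3 by 4-methylphenyl in place of 2-methylphenyl on an amide-type nitrogen. For the measured compounds named here, none of the measured steps swaps one methylphenyl isomer for another, so none bears on this change directly. The nearest guide is the step from compound 1 to compound 3, where removing one methyl from the aromatic ring lowered the number substantially, and the step from compound 2 to compound 3, where replacing a benzyl group by 2-methylphenyl lowered it modestly. These say that the amide substituent matters, but not how the placement of a single methyl matters. Compound 4 is therefore expected to stay close to compound 3 in this assay, with the step of a 1.3-fold higher number from compound 3 to compound 4 (0.13 log units; within the scatter) probably not beyond the scatter, and a value estimated at 80000 nM, within 25000 nM to 300000 nM.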

Compound 4, half-maximal cytotoxic concentration: 979000 nM
Beside the measured number, compound 4's estimate is 12-fold (1.09 log units) below it; the whole stated range lies below it.
By their numbers in this assay, from the lowest: compound 3; then compound 2; then compounds 4 and 1 (each within the scatter of the next).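

For the compounds shown here, the result shows what the earlier compounds could not: with the same atoms joined differently, moving the single methyl on the amide-type nitrogen's aryl group alone gives a 16-fold higher number from compound 3 to compound 4 (1.21 log units; beyond the scatter) in this assay, so the placement of this methyl matters a great deal, not merely the choice of substituent. The same result sets the 2-methylphenyl group of compound 3 apart from the 4-methylphenyl group, which also stands clear of the 4-fluorobenzyl group in a 7.4-fold higher number from compound 2 to compound 4 (0.87 log units; beyond the scatter) and cannot be told from the 2,5-dimethylphenyl group in a 1.1-fold lower number from compound 1 to compound 4 (0.05 log units; within the scatter) on these numbers. Nothing available accounts for why moving the methyl has so large an effect on the tolerated concentration.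

The compounds shown leave open whether the large step belongs to the methyl itself or would recur with another group, such as a methoxy, a chlorine or an amine, in place of the methyl in the 2-methylphenyl and 4-methylphenyl groups. They also leave open whether a longer chain such as ethyl in place of that methyl would behave in the same way.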